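Lengthening the chain on a weak compound

The source may report more compounds than this note shows. Statements on the series, on what has been measured and on what is new or still open speak of the compounds shown alone.

Measured in a functional assay on SW480 cells (Homo sapiens) for antiproliferative activity, read by MTT assay, with a stated time of 48 h; a higher number here means a weaker inhibitor, a lower number a stronger inhibitor:
- compound 1 `CC(CCO)n1cnc2c(Cl)nc(F)nc21`: 16800 nM
- compound 2 `CC(CCO)n1cnc2c(Cl)ncnc21`: > 50000 nM (a limit, not a number)
- compound 3 `CCCCCC(CCO)n1cnc2c(Cl)nc(Cl)nc21`: 6010 nM

Compound 2 sits at the limit of > 50000 nM in this assay, at which 1 of the 3 values shown sits, so it has a limit and no number. Compound 4 `CCCCCCC(CCO)n1cnc2c(Cl)ncnc21` differs from it as follows: pentyl in place of hydrogen on a saturated chain carbon, two bonds along the chain from an aromatic nitrogen. In words, pentyl replaces hydrogen on a saturated chain carbon, two bonds along the chain from an aromatic nitrogen, which turns methyl to hexyl.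

Among the compounds with values here, the one measured step, an at least 2.9-fold higher number from compound 1 to compound 2 (0.47 log units; beyond the scatter), lies at another place in the molecule, so it does not measure this chain change. The nearest hint is compound 3, which carries a pentyl chain and reads 6010 nM, while compound 1 reads 16800 nM. Of the two, compound 3 has the lower number. These two compounds differ in more than one place, so that hint is only loose. On the strength of compound 3 at 6010 nM, a move towards stronger inhibition is expected. The estimated step is an at least 2.7-fold lower number from compound 2 to compound 4 (0.44 log units; beyond the scatter). Compound 4 is expected at about 18000 nM, with an estimated range of 6000 nM to 50000 nM.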

Compound 4, half-maximal inhibitory concentration: 16700 nM
Estimate against measurement, compound 4: 1.1-fold (0.03 log units) above; measured number inside the range.
By their numbers in this assay, from the lowest: compound 3; then compounds 4 and 1 (each within the scatter of the next). At a limit, above all of these: compound 2.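

In this assay, within the data shown here, the change of methyl to hexyl gives an at least 2.9-fold lower number from compound 2 to compound 4 (0.47 log units; beyond the scatter) and so shows that this saturated chain carbon also moves the read-out, whereas the one earlier step concerned only a hydrogen in place of fluoro on an aromatic carbon. A chain as long as hexyl is therefore tolerated at this place on the shared core, and it gives a real number where the methyl compound gave none. As far as these compounds go, the step is only a minimum and its true size stays unknown, since compound 2 has a limit and not a number: the limit of > 50000 nM in this assay, at which 1 of the 4 values shown sits.

From the compounds shown here alone, whether a chain between methyl and hexyl, a longer chain or a chain ending in an amine would do better stays open. So does whether the same chain change would pay on a core that carries fluoro.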